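The compounds below may be only part of what the source reports. "The series", "measured", "known", "first", "only" and "open" are said of these compounds alone.

Measured so far in a functional assay on HT-29 cells (Homo sapiens) for cytotoxicity, read by MTT assay, with a stated time of 48 h; a lower number here means a stronger inhibitor, a higher number a weaker inhibitor
compound 1 `OC[C@@H]1C[C@H](CO)[C@@H]2C(c3ccc(Cl)cc3)=NO[C@H]12` gives 22.9 ug/mL
compound 2 `OC[C@@H]1C[C@H](CO)[C@@H]2C(c3ccc(Br)cc3)=NO[C@H]12` gives 37.3 ug/mL

Going by the values given here, with only two numbers available, compound 1 and compound 2 stand within the usual scatter of repeated measurements of each other. The next compound to be tested is compound 3 `OC[C@@H]1C[C@H](CO)[C@@H]2C(c3ccc(F)cc3)=NO[C@H]12` which keeps the core of compound 1 and alters a single group. The change is fluoro in place of chloro on an aromatic carbon and in plain words it puts fluoro in place of chloro on an aromatic carbon, para to a large group.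

Among the compounds with values here, one measured step bears on this change, since it also replaces the chloro of compound 1 with another group on an aromatic carbon. That step, bromo in place of chloro, is a 1.6-fold higher number from compound 1 to compound 2 (0.21 log units; within the scatter) and it stays within the scatter. Within the data shown here, it is thin evidence, as no fluoro compound has been measured yet. No step beyond the scatter is therefore expected in this assay and no direction can be favoured. The expected step is a 1.1-fold higher number from compound 1 to compound 3 (0.04 log units; within the scatter) and this is only an estimate. For compound 3 the estimated value is 25 ug/mL with an expected range from 12 ug/mL to 50 ug/mL around it.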

Compound 3, half-maximal inhibitory concentration: 17.8 ug/mL
Compound 3: the middle estimate sits 1.4-fold (0.15 log units) above what was measured, and the stated range covers the measured number.
By their numbers in this assay, from the lowest: compounds 3, 1 and 2 (each within the scatter of the next, the first and the last beyond it).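

In this assay, going by these compounds alone, the fluoro compound can now be set against both the chloro and the bromo compound, and the two comparisons do not read alike: the swap for chloro gives a 1.3-fold lower number from compound 1 to compound 3 (0.11 log units; within the scatter) while the swap for bromo gives a 2.1-fold lower number from compound 2 to compound 3 (0.32 log units; beyond the scatter) and is the first step in this small set to pass beyond the usual scatter between repeated measurements. The three halogens at this place on the aromatic ring can therefore no longer all be treated as interchangeable, although the separation is modest and holds only for compound 2 and compound 3, with compound 1 within the scatter of each. No measurement available here explains this gap.

From the compounds shown here alone, all three compounds carry a single halogen at this one place, so it remains open how an amine, a methoxy group or a carboxylic acid there would read in this assay and whether any such group would move the number further than the halogens do. Going by these compounds, the rest of the shared core stays the same throughout, so it is also open how these small differences would hold up if a longer chain were attached elsewhere on it.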